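Pyridyl for fluorophenyl at a cytotoxicity limit

The compounds below may be only part of what the source reports. "The series", "measured", "known", "first", "only" and "open" are said of these compounds alone.

Compound 3 `Cc1ccc2c(NCc3ccc(NC(=O)C4CCN(Cc5ccccc5F)CC4)cc3)nc(N(C)C)nc2c1` stands only at a limit in a functional assay on SV5A8 cells (Homo sapiens) for cytotoxicity; on this read-out lower numbers stand for stronger inhibition and higher numbers for weaker inhibition: compound 3 gives > 6670 nM, a limit of the assay and not a number. Its two neighbours likewise give limits. Compound 1 `Cc1ccc(CN2CCC(C(=O)Nc3ccc(CNc4nc(N(C)C)nc5cc(C)ccc45)cc3)CC2)cc1` gives > 4150 nM in this assay, a limit. Compound 2 `Cc1ccc2c(NCc3ccc(NC(=O)C4CCN(C(=O)OC(C)(C)C)CC4)cc3)nc(N(C)C)nc2c1` gives > 4820 nM in this assay, a limit. The change to compound 4 `Cc1ccc2c(NCc3ccc(NC(=O)C4CCN(Cc5cc(Cl)ccn5)CC4)cc3)nc(N(C)C)nc2c1` is 4-chloropyridin-2-yl in place of 2-fluorophenyl on a saturated chain carbon bound to an amine nitrogen in a ring. The steps that touch the same place, a step that the two limits leave unreadable from compound 1 to compound 3 and a step that the two limits leave unreadable from compound 2 to compound 3, are of unreadable size, so no direction can be drawn from them, and the limit of > 6670 nM in this assay, at which 1 of the 3 values shown sits, is all that is known of compound 3. Compound 4 is therefore expected to stay near the limit, with a step that the limit leaves unreadable from compound 3 to compound 4 as the expected step. The estimate for compound 4 is 7000 nM, from 2500 nM to 25000 nM.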

Compound 4, half-maximal inhibitory concentration: > 5400 nM
Compound 4: a limit, no number; the forecaster's own chance of this, stated with the estimate: 80%; the middle value lies beyond the limit too.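

Compound 4 gives only a limit in this assay, as do compound 1, compound 2 and compound 3, so no step among these four can be read. The compounds shown leave open whether any group on the amine nitrogen in the ring changes this read-out at all.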